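The source may report more compounds than this note shows. Statements on the series, on what has been measured and on what is new or still open speak of the compounds shown alone.

Measured so far in a functional assay on HEK293 cells for agonist activity at D(4) dopamine receptor (Homo sapiens), read by FLIPR; a lower number here means a smaller maximal response, a higher number a larger maximal response:
Compound 1 `Cc1cccc(NC(=O)CN2CCC(c3nccs3)CC2)c1` gives 62%.
Compound 2 `N#Cc1cccc(C(=O)NCN2CCC(c3cccc[n+]3[O-])CC2)c1` gives 69%.
Compound 3 `O=C(CN1CCC(c2cccc[n+]2[O-])CC1)Nc1ccc(F)cc1` gives 71%.

Compound 1 has the lowest of these three numbers, but compound 2 and compound 3 each lie within the usual scatter of it, so the three cannot be told apart with any confidence. Compound 4 `Cc1cccc(NC(=O)CN2CCC(c3ccccc3F)CC2)c1` shares the core of compound 1 and differs from it in one place: 2-fluorophenyl in place of 1,3-thiazol-2-yl on a saturated ring carbon. Going by the values given here, no pair of measured compounds shows a change of this kind, so nothing here says how it acts. The step expected is a number 4 percentage points higher from compound 1 to compound 4 (within the scatter), small and with no direction beyond the scatter that the data could justify. Compound 4 is therefore estimated to give 66% in this assay, between 48% and 84%.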

Compound 4, largest response reached (reported as efficacy), in percent of the reference or control that the assay uses: 57%
For compound 4 the middle estimate is 9 percentage points above the measured one; the measured number falls inside the stated range.
By their numbers in this assay, from the lowest: compounds 4, 1, 2 and 3 (each within the scatter of the next, the first and the last beyond it).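

In this assay, putting 2-fluorophenyl in place of 1,3-thiazol-2-yl on this saturated ring carbon gives a number 5 percentage points lower from compound 1 to compound 4 (within the scatter). This is the first step shown at this position, and it indicates that a five-membered aromatic ring with two hetero atoms and a six-membered aromatic ring of carbon only can occupy this place without a change that stands clear of the scatter. Nothing available explains this result. Still open, as far as these compounds go, is whether a group of a different kind here, such as an amine or a carboxylic acid, would shift the maximal response beyond the scatter.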